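A few compounds are considered here, and "the series" means these few. Any claim that something is new, unique, unknown or untested is made for them only; others in the source may bear on it.

Among the measured compounds shown here, in a functional assay on A549 cells (Homo sapiens) for inhibition, read by colorimetric assay and MTT assay, with a stated time of 72 h (a higher number here means a weaker inhibitor, a lower number a stronger inhibitor), two compounds built on one shared core have numbers so far. Compound 1 `C/C1=C\CC[C@@]2(C)O[C@@H]2[C@H]2OC(=O)[C@@H](CN3CCN(C)CC3)[C@@H]2C[C@H]1O` gives 30000 nM there, and compound 2 `C/C1=C\CC[C@@]2(C)O[C@@H]2[C@H]2OC(=O)[C@@H](CN3CCN(c4ccccc4)CC3)[C@@H]2C[C@H]1O` gives 17000 nM there too. These two values lie within the scatter of each other, so compound 2 stands level with compound 1 and the pair cannot be ranked.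

Compound 3 `C/C1=C\CC[C@@]2(C)O[C@@H]2[C@H]2OC(=O)[C@@H](CN3CCN(c4ccccc4F)CC3)[C@@H]2C[C@H]1O` differs from compound 2 by fluoro in place of hydrogen on an aromatic carbon and nothing else: fluoro in place of hydrogen on an aromatic carbon, which turns phenyl into 2-fluorophenyl. For the measured compounds named here, only one measured step offers any guidance, and it is indirect. Exchanging a methyl group for a phenyl group gave a 1.8-fold lower number from compound 1 to compound 2 (0.25 log units; within the scatter) and so stayed within the scatter. That swap involved a whole phenyl group, yet it produced no clear shift. Going by the values given here, no measured compound carries fluoro, so the data give no direction for this change. In this assay the estimated change is a 1.1-fold lower number from compound 2 to compound 3 (0.05 log units; within the scatter) and no step beyond the scatter is expected. Compound 3 is expected at 15000 nM within an estimated range from 7000 nM to 32000 nM when measured.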

Compound 3, half-maximal inhibitory concentration: 22000 nM
Beside the measured number, compound 3's estimate is 1.5-fold (0.17 log units) below it; the measured number falls inside the stated range.
By their numbers in this assay, from the lowest: compounds 2, 3 and 1 (each within the scatter of the next).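

In this assay, turning phenyl into 2-fluorophenyl, which puts fluoro on an aromatic carbon ortho to a large group, gives a 1.3-fold higher number from compound 2 to compound 3 (0.11 log units; within the scatter), so compound 2 and compound 3 cannot be told apart. Among the compounds shown here, this is the first reading at this aromatic ring itself, and it shows that this single fluorine leaves the number inside the usual spread of repeated measurements. Replacing the methyl of the first compound outright with 2-fluorophenyl gives a 1.4-fold lower number from compound 1 to compound 3 (0.13 log units; within the scatter), so all three compounds stand level here and none can be ranked, and no measured evidence bears on why these numbers sit together.

From the compounds shown here alone, it remains open whether a different group on that same aromatic carbon, such as methoxy, nitrile or a carboxylic acid, would carry the number beyond the scatter. Going by these compounds, it is equally open whether a benzyl group or a longer chain on the ring nitrogen, in place of methyl, phenyl or 2-fluorophenyl, would separate itself from compound 1, compound 2 and compound 3.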